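Chloro to cyano on the fused ring system

The source may hold more compounds than are shown below. What is called first, only, known or untested is meant among the compounds shown, and "the series" means these compounds.

Measured so far:
compound 1, `O=c1c2ccccc2ccn1[C@@H]1O[C@H](COP(=O)(O)OP(=O)(O)OP(=O)(O)O)[C@@H](O)[C@H]1O`, in a functional assay for agonist activity at P2Y purinoceptor 2 (Homo sapiens), read by FLIPR; a lower number here means that less compound is needed, a higher number that more compound is needed for the effect: 31 nM
compound 2, `O=c1c2ccc(Cl)cc2ccn1[C@@H]1O[C@H](COP(=O)(O)OP(=O)(O)OP(=O)(O)O)[C@@H](O)[C@H]1O`, in this assay: 541 nM

Compound 2 stands highest of the two numbers; its nearest neighbour is compound 1, and the step of a 17-fold higher number from compound 1 to compound 2 (1.24 log units; beyond the scatter) lies beyond the scatter. Compound 3, `N#Cc1ccc2c(=O)n([C@@H]3O[C@H](COP(=O)(O)OP(=O)(O)OP(=O)(O)O)[C@@H](O)[C@H]3O)ccc2c1`, carries cyano in place of chloro on an aromatic carbon. Within the data shown here, no measured step covers cyano in place of chloro; the only step known, a 17-fold higher number from compound 1 to compound 2 (1.24 log units; beyond the scatter), shows that a group at this place can move the number strongly. Compound 3 is therefore expected to stay close to compound 2, with wide uncertainty. For compound 3 the estimate is 400 nM, range 80 nM to 2000 nM. The expected step is a 1.4-fold lower number from compound 2 to compound 3 (0.13 log units; within the scatter).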

Compound 3, half-maximal effective concentration: 88 nM
Compound 3: middle estimate off by 4.5-fold (0.66 log units), on the high side; low and high end bracket the measured number.
By their numbers in this assay, from the lowest: compound 1; then compound 3; then compound 2.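

In this assay, the number at this place depends strongly on which group sits there: cyano in place of chloro gives a 6.1-fold lower number from compound 2 to compound 3 (0.79 log units; beyond the scatter), so the full rise seen with chloro is not shared by every group. Cyano in place of hydrogen still gives a 2.8-fold higher number from compound 1 to compound 3 (0.45 log units; beyond the scatter), so neither group on this aromatic carbon matches the unsubstituted core of compound 1. No evidence is available on why the two groups differ.

From the compounds shown here alone, whether an amine, a carboxylic acid or a longer chain at this place would give a number nearer to compound 1 remains open. Also open, going by these compounds, is whether any group here could give a lower number than compound 1.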